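Replacing the amide of compound 3 with an anilinomethyl chain

The source may report more compounds than this note shows. Statements on the series, on what has been measured and on what is new or still open speak of the compounds shown alone.

Compound 1 `COc1ncc(NC(=O)[C@H](C)[C@H]2CC[C@@H](c3ccnc4ccc(F)cc43)CC2)cn1`, in an assay on tissue (HeLa cells) for inhibition of Indoleamine 2,3-dioxygenase 1 (Homo sapiens), with stated times of 2 h and 18 h (on this read-out lower numbers stand for stronger inhibition and higher numbers for weaker inhibition), compound 1 gives 10 nM.
Compound 2 `C[C@H](NC(=O)[C@H](C)[C@H]1CC[C@@H](c2ccnc3ccc(F)cc32)CC1)c1ccc(Cl)cc1`, in this assay compound 2 gives 67 nM.
Compound 3 `C[C@@H](C(=O)NC1CCCCC1)[C@H]1CC[C@@H](c2ccnc3ccc(F)cc32)CC1`, in this assay compound 3 gives 18 nM.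

Compound 3 stands second highest of the three numbers; its nearest neighbour is compound 1, with a 1.8-fold higher number from compound 1 to compound 3 (0.26 log units; within the scatter), and its furthest is compound 2, with a 3.7-fold lower number from compound 2 to compound 3 (0.57 log units; beyond the scatter). Compound 4 `C[C@@H](CNc1ccc(Cl)cc1)[C@H]1CC[C@@H](c2ccnc3ccc(F)cc32)CC1` is not yet measured. It differs from compound 3 in one place: ((4-chlorophenyl)amino)methyl in place of cyclohexylcarbamoyl on a saturated chain carbon bound to a saturated chain carbon and a saturated ring carbon. The carbonyl therefore leaves, and a 4-chlorophenyl group arrives on a nitrogen that now sits one saturated carbon further from the core.

Among the measured compounds shown here, none of the measured steps changes this part of the molecule; all three vary only the group on the amide nitrogen while keeping the carbonyl. The step of a 3.7-fold lower number from compound 2 to compound 3 (0.57 log units; beyond the scatter) is the only one that brings a 4-chlorophenyl group into view, and there the compound carrying it had the higher number. On that slim basis compound 4 is expected to give a higher number than compound 3, with the step estimated as an 8.3-fold higher number from compound 3 to compound 4 (0.92 log units; beyond the scatter). The estimate for compound 4 in this assay is 150 nM, with a range from 40 nM to 600 nM.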

Compound 4, half-maximal inhibitory concentration: 7 nM
Beside the measured number, compound 4's estimate is 21-fold (1.33 log units) above it; measured number below the stated range.
By their numbers in this assay, from the lowest: compounds 4, 1 and 3 (each within the scatter of the next, the first and the last beyond it); then compound 2.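

Among the compounds shown here, compound 4 is the first compound here in which the carbonyl is gone and the position itself changes, and in this assay the swap of cyclohexylcarbamoyl for ((4-chlorophenyl)amino)methyl gives a 2.6-fold lower number from compound 3 to compound 4 (0.41 log units; beyond the scatter), a modest step beyond the scatter. The earlier steps shown here varied only the group on the amide nitrogen, so they could not show that, for this pair, a low number survives the loss of the carbonyl and that a chain ending in a 4-chlorophenyl group can carry one. The step changes the carbonyl, the ring and the distance of the nitrogen from the core all at once, so it cannot be assigned to any one of them, and nothing measured here gives a reason for it.

Still open, from the compounds shown here alone, is how a cyclohexylaminomethyl group or a 4-chlorophenyl amide would read in this assay, since either would separate the loss of the carbonyl from the change of ring. Also open, going by these compounds, is whether the nitrogen of the new chain matters, which an ether oxygen or a methylene in its place would test.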